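The source may report more compounds than this note shows. Statements on the series, on what has been measured and on what is new or still open speak of the compounds shown alone.

Values in a functional assay on OVCAR-3 cells (Homo sapiens) for inhibition, read by sulforhodamine B assay, with a stated time of 48 h (a lower number here means a stronger inhibitor of growth, a higher number a weaker inhibitor of growth), for the measured compounds:

compound 1 `COc1ccc(/C=C/C2CC=CC(=O)O2)c(OC)c1`: 5.6 uM
compound 2 `COc1cc(OC)c(OC)cc1/C=C/C1CC=CC(=O)O1`: 7.2 uM
compound 3 `COc1ccc(/C=C/C2CC=CC(=O)N2)cc1`: 787 uM

Compound 2 differs from compound 1 by methoxy in place of hydrogen on an aromatic carbon; the result is a 1.3-fold higher number from compound 1 to compound 2 (0.11 log units; within the scatter). Compound 3 stands far from the other two, and the difference between the core of compound 3 and the core of compound 1 is not broken down here.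

Compound 4 `COc1ccc(/C=C/C2CC=CC(=O)N2)c(OC)c1` is not yet measured. It differs from compound 3 by methoxy in place of hydrogen on an aromatic carbon. This is the same kind of change as from compound 1 to compound 2, not the same: there the entering methoxy was ortho to a methoxy group, meta to a group of 9 heavy atoms and para to a methoxy group; here it is ortho to a group of 9 heavy atoms and meta to a methoxy group. Resting on a 1.3-fold higher number from compound 1 to compound 2 (0.11 log units; within the scatter), which lies within the scatter, a step of similar size is expected: a 1.2-fold lower number from compound 3 to compound 4 (0.08 log units; within the scatter). Compound 4 is therefore estimated at 650 uM in this assay, between 220 uM and 1900 uM.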

Compound 4, concentration for growth inhibition (reported as GI): > 964 uM
Compound 4 ended at the assay's limit; the forecaster's own chance of this, stated with the estimate: 25%; middle value at least 1.4-fold (0.17 log units) from the limit.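

In this assay compound 4 gives > 964 uM, a limit of the assay and not a number. Methoxy in place of hydrogen on an aromatic carbon gives an at least 1.2-fold higher number from compound 3 to compound 4 (0.08 log units; that floor lies within the scatter), so only a floor is known for this step and its full size is not shown. Nothing here shows that the change keeps the same size when carried from the core of compound 1 to the core of compound 3, or that it does not: the same change on two cores in this assay, a 1.3-fold higher number (0.11 log units; within the scatter) from compound 1 to compound 2 and an at least 1.2-fold higher number (0.08 log units; that floor lies within the scatter) from compound 3 to compound 4; the limit leaves it open whether they differ

The compounds shown leave open how a group other than methoxy on this aromatic carbon, such as an amine or a carboxylic acid, would read on either core. They also leave open how a methoxy on this core would read in a range where the assay returns a number rather than a limit.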